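The source may report more compounds than this note shows. Statements on the series, on what has been measured and on what is new or still open speak of the compounds shown alone.

In a physicochemical assay for lipophilicity, using the shake flask method, measured as octanol-water partition, at pH 7.4 (a lower number here means a more polar compound, a higher number a more lipophilic compound), compound 1 `CC(=O)N[C@@H]1CCC[C@H](C(=O)Nc2cc(-c3cnn4ccccc34)c(Cl)cn2)C1` gives 3.6, compound 2 `CC(=O)N[C@@H]1CCC[C@H](C(=O)Nc2cc(-c3nnn4ccccc34)c(Cl)cn2)C1` gives 2 and compound 3 `CC(=O)N[C@@H]1CCC[C@H](C(=O)Nc2cc(-c3cnn4c3CN(C)CC4)c(Cl)cn2)C1` gives 2.1. Compound 3 therefore stands well under compound 1 and level with compound 2. Compound 4 `CC(=O)N[C@@H]1CCC[C@H](C(=O)Nc2cc(-c3cnn4c3OCCC4)c(Cl)cn2)C1` carries a group of 9 heavy atoms (6 carbon, 2 nitrogen, 1 oxygen; one five-membered aromatic ring with 2 hetero atoms, one six-membered non-aromatic ring with 2 hetero atoms) in place of a group of 10 heavy atoms (7 carbon, 3 nitrogen; one five-membered aromatic ring with 2 hetero atoms, one six-membered non-aromatic ring with 2 hetero atoms), on an aromatic carbon, ortho to a chloro group. Three measured steps change the group at this same place. Two are large: a number 1.60 log units lower from compound 1 to compound 2 (beyond the scatter) and a number 1.50 log units lower from compound 1 to compound 3 (beyond the scatter). The third, a number 0.10 log units higher from compound 2 to compound 3 (within the scatter), is not. For the measured compounds named here, no measured step exchanges the two groups at issue, so only a moderate rise is expected, well short of the large steps. In this assay, the expected step is a number 0.40 log units higher from compound 3 to compound 4 (beyond the scatter). Compound 4 is estimated at 2.5, with an expected range of 2.1 to 2.9.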

Compound 4, distribution coefficient: 2.6
Estimate against measurement, compound 4: 0.10 log units below; the range from low to high includes it.
By their numbers in this assay, from the lowest: compounds 2 and 3 (each within the scatter of the next); then compound 4; then compound 1.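

Compounds 3 and 4 share the same ring types and hydrogen-bond counts, yet the exchange at this position still registers in this assay (a number 0.50 log units higher from compound 3 to compound 4 (beyond the scatter)), so those shared features do not fix the value. The group of 9 heavy atoms with 1 oxygen also separates from the aromatic group of compound 2 (a number 0.60 log units higher from compound 2 to compound 4 (beyond the scatter)), while staying clear of the group in compound 1 (a number 1.00 log units lower from compound 1 to compound 4 (beyond the scatter)). Nothing available explains these steps.

Where a carboxylic acid or a primary amine on the non-aromatic ring would fall remains open. So does whether these steps hold on another core.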